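The source may report more compounds than this note shows. Statements on the series, on what has been measured and on what is new or still open speak of the compounds shown alone.

In a physicochemical assay for solubility, in phosphate buffer, measured as kinetic solubility, at pH 7.4 (a higher number here means a more soluble compound, a lower number a less soluble compound), compound 1 (`Cc1ccccc1-c1nc(CN2CCC(C(=O)NCCCN3CCCC(CC(C)C)C3)CC2)c(C)o1`) gives 54.9 ug/mL. Compound 2 (`Cc1ccccc1-c1nc(CN2CCC(C(=O)NCCCN3CC4CCCC(C4)C3)CC2)c(C)o1`) stands at > 71 ug/mL, which is a limit of the assay and not a number. On these data alone, the picture therefore holds (the limit of > 71 ug/mL in this assay, at which 1 of the 2 values shown sits), so the true position of compound 2 remains unknown.

Compound 3 (`Cc1ccccc1-c1nc(CN2CCC(C(=O)NCCCCN3C[C@H](C)C[C@H](C)C3)CC2)c(C)o1`) keeps the shared core, and the change from compound 2 is a group of 9 heavy atoms (8 carbon, 1 nitrogen; one six-membered non-aromatic ring with 1 hetero atom) in place of a group of 9 heavy atoms (8 carbon, 1 nitrogen; one six-membered non-aromatic ring of carbon only, one six-membered non-aromatic ring with 1 hetero atom), on a saturated chain carbon, three bonds along the chain from an amide-type nitrogen. The (3,5-dimethylpiperidin-1-yl)methyl group enters on a saturated chain carbon, three bonds along the chain from an amide-type nitrogen.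

Among the compounds with values here, only one measured step bears on this place: an at least 1.2-fold higher number from compound 1 to compound 2 (0.11 log units; that floor lies within the scatter). That step also exchanges one group for another at this position, but it gives a floor rather than a measured size. Within the data shown here, compound 1, at 54.9 ug/mL, is the only firm number nearby, so the expectation leans on it. In this assay, no change beyond the scatter is expected, and the estimated step is an at least 1.1-fold lower number from compound 2 to compound 3 (0.07 log units; that floor lies within the scatter). For compound 3 the expected value is 60 ug/mL, with an estimated range from 30 ug/mL to 90 ug/mL.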

Compound 3, solubility: > 71 ug/mL
Compound 3 gave a limit, no number (the forecaster's own chance of this, stated with the estimate: 35%); middle value at least 1.1-fold (0.07 log units) away from the limit.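

In this assay compound 3 gives > 71 ug/mL, which is a limit of the assay and not a number. Within the data shown here, the only step that can be read is an at least 1.2-fold higher number from compound 1 to compound 3 (0.11 log units; that floor lies within the scatter), so the (3,5-dimethylpiperidin-1-yl)methyl group reaches the same limit as the two-ring group of compound 2, and a second ring at this place is not needed to get there. Steps that join two limits cannot be read, so the change from compound 2 to compound 3 has no measurable size, and the data now crowd at one end of the scale: the limit of > 71 ug/mL in this assay, at which 2 of the 3 values shown sit.

On these data alone, the true values of compound 2 and compound 3 remain unknown, as does any real difference between their two groups on a saturated chain carbon, three bonds along the chain from an amide-type nitrogen. As far as these compounds go, it is also open whether a morpholine ring or a carboxylic acid at this place would give a firm number that could be compared directly with compound 1.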